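Working notes on the shared core: the step to compound 4

The source may hold more compounds than are shown below. What is called first, only, known or untested is meant among the compounds shown, and "the series" means these compounds.

Measured so far in an assay on mitochondria from L6 cells (Rattus norvegicus) for activation, with a stated time of 90 min; a higher number here means that more compound is needed for the effect, a lower number that less compound is needed:
compound 1, `Cc1ccccc1Nc1nc2nonc2nc1Nc1ccccc1F`, 1100 nM
compound 2, `Cc1cccc(Nc2nc3nonc3nc2Nc2ccccc2F)c1`, 1500 nM
compound 3, `Fc1ccccc1Nc1nc2nonc2nc1Nc1cccc(C(F)(F)F)c1`, a limit of the assay, < 1000 nM

Among the two numbers, compound 2 gives the highest in this assay, at 1500 nM. The nearest number belongs to compound 1, and the step of a 1.4-fold higher number from compound 1 to compound 2 (0.13 log units; within the scatter) is within the scatter. For compound 3 only a limit is reported, < 1000 nM. The step of an at least 1.5-fold lower number from compound 2 to compound 3 (0.17 log units; that floor lies within the scatter) is bounded by that limit, and the floor of the step sits within the scatter, as noted under (the limit of < 1000 nM in this assay, at which 1 of the 3 values shown sits).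

Compound 4 is `Oc1ccc(F)c(Nc2nc3nonc3nc2Nc2ccccc2F)c1`. It differs from compound 2 in one place: 2-fluoro-5-hydroxyphenyl in place of 3-methylphenyl on a nitrogen on an aromatic ring. Neither measured step matches this change. The step from compound 1 to compound 2 moves a methyl within the ring, and the step from compound 2 to compound 3 exchanges methyl for trifluoromethyl on an aromatic carbon; both are within the scatter. Among the measured compounds shown here, no measured step introduces a hydroxyl or a second fluorine on this ring. The expectation for compound 4 in this assay is therefore a step of about a 1.4-fold lower number from compound 2 to compound 4 (0.13 log units; within the scatter), within the scatter, with no clear direction. Compound 4 is estimated at 1100 nM, in the range 400 nM to 3000 nM.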

Compound 4, half-maximal effective concentration: 30000 nM
The estimate for compound 4 lay 27-fold (1.44 log units) below the measured number, outside the stated range (above it).
By their numbers in this assay, from the lowest: compounds 1 and 2 (each within the scatter of the next); then compound 4. At a limit, below all of these: compound 3.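

In this assay, this place on the shared core, on a nitrogen on an aromatic ring, now shows a clear response to the group it carries: 2-fluoro-5-hydroxyphenyl in place of 3-methylphenyl gives a 20-fold higher number from compound 2 to compound 4 (1.30 log units; beyond the scatter) and, in place of 2-methylphenyl, gives a 27-fold higher number from compound 1 to compound 4 (1.44 log units; beyond the scatter) as well. Among the compounds shown here, compounds 1 and 2 lie within the scatter of each other, so the two methylphenyl groups gave no sign that this place could move the number so far, and the series now shows that not every substituted phenyl group is equivalent here. Nothing measured among these compounds accounts for the size of these steps.

The entering group brings a hydroxyl and a fluorine together, so the compounds shown do not separate the share of each, and a phenyl group carrying only one of the two would be needed to do that. Also open, as far as these compounds go, is how this place responds to a methoxy group, an amine or a carboxylic acid on the same ring.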